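A few compounds are considered here, and "the series" means these few. Any claim that something is new, unique, unknown or untested is made for them only; others in the source may bear on it.

In an ADME assay for permeability, using PAMPA, at pH 7.4 (on this read-out higher numbers stand for higher permeability and lower numbers for lower permeability), compound 1 (`CSc1ccc(NC(=O)Nc2cc(C)nc3ccccc23)cc1`) gives 473 10^-6 cm/s and compound 2 (`Cc1cc(NC(=O)Nc2ccc(F)cc2)c2ccccc2n1`) gives 801 10^-6 cm/s. These two numbers lie within the usual scatter of each other, so compound 2 stands level with compound 1 on the evidence so far, and the pair does not yet define a trend. The next compound to be measured is compound 3 (`Cc1cc(NC(=O)Nc2ccc(C(F)(F)F)cc2)c2ccccc2n1`), which carries trifluoromethyl in place of fluoro on an aromatic carbon, para to a large group: trifluoromethyl in place of fluoro on an aromatic carbon. Among the measured compounds shown here, only one measured step bears on this change, an exchange on an aromatic carbon of the same kind. Resting on a 1.7-fold higher number from compound 1 to compound 2 (0.23 log units; within the scatter), no step beyond the scatter is expected in this assay for the new exchange. For the measured compounds named here, that is a thin basis, since it is a single step and no measured compound carries trifluoromethyl. The estimated change is a 1.1-fold lower number from compound 2 to compound 3 (0.03 log units; within the scatter). For compound 3 the expected value is 750 10^-6 cm/s, with an estimated range from 300 10^-6 cm/s to 1700 10^-6 cm/s.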

Compound 3, apparent permeability: 2 10^-6 cm/s
Estimate against measurement, compound 3: 380-fold (2.57 log units) above; measured number outside the range, below it.
By their numbers in this assay, from the lowest: compound 3; then compounds 1 and 2 (each within the scatter of the next).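

In this assay the change of trifluoromethyl for fluoro, on an aromatic carbon para to a large group, gives a 400-fold lower number from compound 2 to compound 3 (2.60 log units; beyond the scatter) in this account, and the change of trifluoromethyl for methylsulfanyl at the same place gives a 240-fold lower number from compound 1 to compound 3 (2.37 log units; beyond the scatter) as well. Fluoro and methylsulfanyl had stayed within the scatter of each other, so the earlier pair gave no sign that this position could matter; it now appears that the group held here can move the number by a large step, and of the three compounds shown, compound 3 alone stands apart from the other two. Nothing among the data shown accounts for the size of this step.

The three compounds leave open whether the low number belongs to trifluoromethyl alone or would also come with other groups at this place, such as chlorine, a nitrile, a methoxy group or an amine. They also leave open whether the same exchange would give a step of this size on a core other than the one shared here, or at another carbon of the same ring.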